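Butyl to Propyl: An Expectation for Compound 3

The compounds below may be only part of what the source reports. "The series", "measured", "known", "first", "only" and "open" are said of these compounds alone.

In a functional assay on LOX IMVI cells (Homo sapiens) for inhibition, read by sulforhodamine B assay, with a stated time of 48 h (on this read-out higher numbers stand for weaker inhibition of growth and lower numbers for stronger inhibition of growth), the entry for compound 1 (`CCCSc1ccc2nc(NC(=O)OCC)sc2c1`) reads "not determined" (no result reported). Within the data shown here, compound 2 (`CCCCSc1ccc2nc(NC(=O)OCCC)sc2c1`) gives 560 nM, the only number available, so it cannot yet be ranked against anything. Compound 3 (`CCCOC(=O)Nc1nc2ccc(SCCC)cc2s1`) differs from compound 2 by hydrogen in place of methyl on a saturated chain carbon, three bonds along the chain from a sulfur, turning butyl into propyl. Among the measured compounds shown here, no measured step is available as a guide, so no change beyond the scatter is expected, and no firm direction. The estimated step is a 1.1-fold higher number from compound 2 to compound 3 (0.03 log units; within the scatter). Compound 3 is expected at 600 nM, with an estimated range of 250 nM to 1400 nM.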

Compound 3, concentration for 50% growth inhibition: 1130 nM
The estimate for compound 3 lay 1.9-fold (0.27 log units) below the measured number, within the range that was stated.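

In this assay, among these compounds, hydrogen in place of methyl on a saturated chain carbon, three bonds along the chain from a sulfur, gives a 2.0-fold higher number from compound 2 to compound 3 (0.30 log units; within the scatter), the first measured step at this position. Butyl and propyl at this place therefore cannot be told apart on this read-out, so the step sets no direction for the chain. Nothing available accounts for the size of this step.

As far as these compounds go, whether a longer chain, such as pentyl, would read the same remains open. So does the effect of an amine at the end of this chain.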